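Swapping methyl for fluoro on an aromatic carbon

This account rests on a few compounds, and the source may have more. Where it says the series, first, only, none or still open, it means among the compounds named here.

Measured in a functional assay on HGC-27 cells (Homo sapiens) for cytotoxicity, read by MTT assay, with a stated time of 72 h; on this read-out higher numbers stand for weaker inhibition and lower numbers for stronger inhibition:
- Compound 1 `O=C1C=CCC/C1=C\C=C\c1ccccc1`: 4500 nM
- Compound 2 `Cc1ccc(/C=C/C=C2\CCC=CC2=O)cc1`: 8100 nM

Going by the values given here, on these numbers, compound 2 cannot be told apart from compound 1, the only other compound measured, since the two lie within the scatter of each other. The next compound, compound 3 `O=C1C=CCC/C1=C\C=C\c1ccc(F)cc1`, departs from compound 2 at one place: fluoro in place of methyl on an aromatic carbon. In words, this is fluoro in place of methyl on an aromatic carbon.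

Among the compounds with values here, only one measured step bears on that carbon, methyl in place of hydrogen, and it is small: a 1.8-fold higher number from compound 1 to compound 2 (0.26 log units; within the scatter). Within the data shown here, no measured step involves fluoro, so the data offer no direct guide to that group. Given compound 1 at 4500 nM and compound 2 at 8100 nM, a further swap at this carbon is expected to bring no step beyond the scatter in this assay. The estimated step is a 1.5-fold lower number from compound 2 to compound 3 (0.17 log units; within the scatter), which would stay inside that scatter. Compound 3 is expected at 5500 nM, with an estimated range from 2500 nM to 12000 nM.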

Compound 3, half-maximal inhibitory concentration: 2300 nM
The estimate for compound 3 lay 2.4-fold (0.38 log units) above the measured number, outside the stated range (below it).
By their numbers in this assay, from the lowest: compounds 3, 1 and 2 (each within the scatter of the next, the first and the last beyond it).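

In this assay, going by these compounds alone, the exchange of methyl for fluoro on an aromatic carbon, para to a large group, gives a 3.5-fold lower number from compound 2 to compound 3 (0.55 log units; beyond the scatter) and is the first step at this place to pass beyond the scatter, which shows that the choice of group on this carbon can register on this read-out. Fluoro in place of hydrogen amounts to a 2.0-fold lower number from compound 1 to compound 3 (0.29 log units; within the scatter) and so does not separate compound 3 from compound 1; the difference appears only when the two substituted compounds, compound 2 and compound 3, are set against each other. Nothing available accounts for that difference between methyl and fluoro.

The compounds shown compare only hydrogen, methyl and fluoro on this carbon, so it remains open whether chloro, bromo, methoxy, an amine or a carboxylic acid there would fall with compound 3, with compound 2 or outside both. They also leave open whether the same exchange would give a step of similar size on a different core or in a different cell line.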